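The compounds below may be only part of what the source reports. "The series", "measured", "known", "first", "only" and "open" are said of these compounds alone.

In an ADME assay on THP-1 cells (Homo sapiens) for cytotoxicity (a lower number here means a stronger inhibitor, a higher number a weaker inhibitor), compound 1 `COc1ccccc1-c1nnc(-c2ccc(C(=O)N/N=C/c3cccc(F)c3)cc2)o1` gives 353000 nM.
In this assay compound 2 `COc1ccc(O)c(/C=N/NC(=O)c2ccc(-c3nnc(-c4ccccc4OC)o3)cc2)c1` gives 303000 nM.

Among the compounds with values here, compound 1 holds the upper of the two measured numbers, yet the only step to it, a 1.2-fold lower number from compound 1 to compound 2 (0.07 log units; within the scatter), does not reach beyond the scatter. Compound 3 `COc1ccc(/C=N/NC(=O)c2ccc(-c3nnc(-c4ccccc4OC)o3)cc2)cc1O` differs from compound 1 at one place: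

3-hydroxy-4-methoxyphenyl in place of 3-fluorophenyl on a carbon with a double bond to nitrogen

The step from compound 1 to compound 2 also exchanged the 3-fluorophenyl for a ring carrying one hydroxy and one methoxy group, and it stayed within the scatter; compound 3 carries the same two groups in a different arrangement. Compound 3 is therefore expected to give 320000 nM (range 150000 nM to 650000 nM), a step of a 1.1-fold lower number from compound 1 to compound 3 (0.04 log units; within the scatter) that is expected to remain within the scatter.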

Compound 3, half-maximal inhibitory concentration: 260000 nM
Beside the measured number, compound 3's estimate is 1.2-fold (0.09 log units) above it; the measured number falls inside the stated range.
By their numbers in this assay, from the lowest: compounds 3, 2 and 1 (each within the scatter of the next).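

In this assay, the new compound tests a second arrangement of the hydroxy and methoxy groups on the ring attached to the carbon with a double bond to nitrogen. Exchanging 3-fluorophenyl for 3-hydroxy-4-methoxyphenyl gives a 1.4-fold lower number from compound 1 to compound 3 (0.13 log units; within the scatter), while exchanging 2-hydroxy-5-methoxyphenyl for it gives a 1.2-fold lower number from compound 2 to compound 3 (0.07 log units; within the scatter), so neither the exchange nor the rearrangement separates these compounds. No available evidence bears on this result.

All three compounds carry a substituted phenyl ring at this place. From the compounds shown here alone, whether an amine or a carboxylic acid there would move the number beyond the scatter remains open.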